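From nonyl to tert-butoxy on compound 1

The compounds below may be only part of what the source reports. "The series", "measured", "known", "first", "only" and "open" are said of these compounds alone.

Among the compounds with values here, in a functional assay on HeLa cells (Homo sapiens) for cytotoxicity, with a stated time of 72 h (on this read-out lower numbers stand for higher toxicity in this test and higher numbers for lower toxicity in this test), compound 1 `CCCCCCCCCCCC/C=C\N(NC(=O)COC)C(=O)CCCCCCCCC` gives 108000 nM as the only true number in this small set. Compound 2 `CCCCCCCCCCCCCCN(NC(=O)COC)C(=O)CCCCCCCCC` gives > 110000 nM here, and that is a limit of the assay, not a number. Compound 3 `CCCCCCCCCCN(NC(=O)COC)C(=O)CCCCCCCCC` gives > 125000 nM here, which is likewise a limit. So compound 1 cannot be ranked against the other two.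

Compound 4 `CCCCCCCCCCCC/C=C\N(NC(=O)COC)C(=O)OC(C)(C)C` has not yet been tested. It keeps the core of compound 1 but carries tert-butoxy in place of nonyl on a carbonyl carbon, a change counted as tert-butoxy in place of nonyl on a carbonyl carbon here. Within the data shown here, only one measured step involves a chain change at all: a step that the two limits leave unreadable from compound 2 to compound 3 here, hydrogen in place of butyl on a saturated chain carbon. That step sits on a different chain and its size cannot be read, so it offers nothing to carry over. Among the measured compounds shown here, no measured compound carries tert-butoxy either. With no size to lean on, no shift beyond the usual scatter is expected in this assay for this swap, and the estimated step is a 1.1-fold higher number from compound 1 to compound 4 (0.05 log units; within the scatter) in size. For compound 4 the expected value is 120000 nM as a best guess, with an estimated range of 60000 nM to 240000 nM around it.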

Compound 4, half-maximal cytotoxic concentration: 85300 nM
Estimate against measurement, compound 4: 1.4-fold (0.15 log units) above, within the range that was stated.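

Within the data shown here, compound 4 gives this series its first readable step at the carbonyl carbon, since the only earlier step between measured compounds is lost to two limits and sits on a different chain: in this assay, the change runs a 1.3-fold lower number from compound 1 to compound 4 (0.10 log units; within the scatter). This swap is far from small on paper, as nonyl, with its 9 heavy atoms, all carbon, leaves and the shorter tert-butoxy, with 5 heavy atoms and 1 hydrogen-bond acceptor, enters, yet compound 1 and compound 4 cannot be told apart in this test, so the long nonyl chain on this carbonyl carbon is not needed to keep the read-out where it stands. Nothing in the data shown gives a reason for this result.

As far as these compounds go, this is one step on one core, so it remains open whether the same swap would also leave the read-out within the scatter on the saturated chain of compound 2. From the compounds shown here alone, it is equally open whether a group of another kind on this carbonyl carbon, such as an amine, a carboxylic acid or a longer chain, would move the value beyond the scatter.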